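From 4-methoxyphenyl to 3,4-dichlorophenyl: working notes

The compounds below may be only part of what the source reports. "The series", "measured", "known", "first", "only" and "open" are said of these compounds alone.

Compound 1 `COc1cccc(/C=C2\CCC/C(=C\c3cccc(OC)c3OC)C2=O)c1`: 16400 nM
Compound 2 `COc1ccc(/C=C2\CCC/C(=C\c3cccc(OC)c3OC)C2=O)cc1`: > 20000 nM (a limit)

Both entries come from a functional assay on A549 cells (Homo sapiens) for cytotoxicity, read by MTT assay, with a stated time of 72 h; a higher number here means a weaker inhibitor, a lower number a stronger inhibitor. Compound 2 stands at > 20000 nM, which is a limit of the assay and not a number. Compound 3 `COc1cccc(/C=C2\CCC/C(=C\c3ccc(Cl)c(Cl)c3)C2=O)c1OC` differs from compound 2 as follows: 3,4-dichlorophenyl in place of 4-methoxyphenyl on a double-bonded chain carbon bound to a double-bonded ring carbon. For the measured compounds named here, the only measured step, an at least 1.2-fold higher number from compound 1 to compound 2 (0.08 log units; that floor lies within the scatter), is a swap at the same place, and it gives little guide to size. Going by the values given here, compound 1, at 16400 nM, holds the only true number, so the expectation stays near it. The expected change is a modest shift to a lower number, estimated as an at least 1.8-fold lower number from compound 2 to compound 3 (0.25 log units; that floor lies within the scatter). Compound 3 is estimated at 11000 nM, with an expected range of 4000 nM to 28000 nM.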

Compound 3, half-maximal inhibitory concentration: > 20000 nM
Compound 3 gave a limit, no number (the forecaster's own chance of this, stated with the estimate: 25%); at least 1.8-fold (0.25 log units) between middle value and limit.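

In this assay compound 3 stands at a limit, > 20000 nM, so a second group on a double-bonded chain carbon bound to a double-bonded ring carbon yields no number. The swap of 3-methoxyphenyl for 3,4-dichlorophenyl gives an at least 1.2-fold higher number from compound 1 to compound 3 (0.08 log units; that floor lies within the scatter), while the step between compound 2 and compound 3 cannot be read. The series now gathers at one limit: the limit of > 20000 nM in this assay, at which 2 of the 3 values shown sit.

As far as these compounds go, whether 3,4-dichlorophenyl and 4-methoxyphenyl differ at all stays open. Also open, from the compounds shown here alone, is what an aminophenyl or a carboxyphenyl group would give at this place.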